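The source may hold more compounds than are shown below. What is called first, only, known or untested is meant among the compounds shown, and "the series" means these compounds.

Three amides on a shared core have been tested so far in a functional assay on HCT-116 cells (Homo sapiens) for antiproliferative activity, read by MTT assay, with a stated time of 72 h (a lower number here means a stronger inhibitor, a higher number a weaker inhibitor), with closely matching results. Compound 1 (`CC(=O)N(C)c1ccc2[nH]c(-c3n[nH]c4ccccc34)cc2n1`) gives 14800 nM here, compound 2 (`CCC(=O)N(C)c1ccc2[nH]c(-c3n[nH]c4ccccc34)cc2n1`) gives 10800 nM here, and compound 3 (`CN(C(=O)C(C)(C)C)c1ccc2[nH]c(-c3n[nH]c4ccccc34)cc2n1`) gives 18000 nM here. Compound 3 thus stands level with the other two: the steps (a 1.2-fold higher number from compound 1 to compound 3 (0.09 log units; within the scatter)) and (a 1.7-fold higher number from compound 2 to compound 3 (0.22 log units; within the scatter)) lie within the scatter, as does the remaining one (a 1.4-fold lower number from compound 1 to compound 2 (0.14 log units; within the scatter)). Compound 4 (`CN(C(=O)c1ccc(Cl)cc1)c1ccc2[nH]c(-c3n[nH]c4ccccc34)cc2n1`) carries 4-chlorophenyl in place of tert-butyl on a carbonyl carbon. The three measured steps bear on this change only in part. Going by the values given here, they show no shift beyond the scatter across compound 1, compound 2 and compound 3, but none of them brings in a ring, so no measured step covers this change directly. No step beyond the scatter is therefore expected in this assay and no direction is favoured, though the margin stays wide. The estimated step is (a 1.4-fold lower number from compound 3 to compound 4 (0.14 log units; within the scatter)). Compound 4 is expected to read 13000 nM (estimated range 5000 nM to 35000 nM).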

Compound 4, half-maximal inhibitory concentration: 3000 nM
Beside the measured number, compound 4's estimate is 4.3-fold (0.64 log units) above it; the whole stated range lies above it.
By their numbers in this assay, from the lowest: compound 4; then compounds 2, 1 and 3 (each within the scatter of the next).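

Going by these compounds alone, on the carbonyl carbon, the earlier compounds showed no shift beyond the scatter among methyl, ethyl and tert-butyl, but 4-chlorophenyl, the only group here that brings in a ring, moves the reading beyond it in this assay (a 6.0-fold lower number from compound 3 to compound 4 (0.78 log units; beyond the scatter); a 3.6-fold lower number from compound 2 to compound 4 (0.56 log units; beyond the scatter); a 4.9-fold lower number from compound 1 to compound 4 (0.69 log units; beyond the scatter)). This position is therefore not indifferent to the group it carries, and all three steps run the same way, though each is modest in size. Nothing available here explains the change or shows whether the ring or the chlorine accounts for it.

From the compounds shown here alone, whether a plain phenyl group would read like compound 4 remains open, and so does whether a saturated ring such as cyclohexyl would. A 4-methoxyphenyl group on the same carbonyl carbon would test whether the chlorine can be replaced without losing the shift.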